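The compounds below may be only part of what the source reports. "The series", "measured", "known", "first", "only" and "open" are said of these compounds alone.

Working notes on the sulfonamide series. For the measured compounds named here, compound 1 `CC1CCN(C2CCN(S(=O)(=O)c3cccc(-c4ccc(F)cc4)c3)CC2)CC1` gives 1.28 h in an ADME assay on S9 fraction from liver (Mus musculus, strain ICR/CD-1) for metabolic stability, read by LC-MS, using NADPH, with a stated time of 5 min, tested at 2 uM (a higher number here means that the compound lasts longer, a lower number that the compound disappears faster), and compound 3 `COc1ccc(-c2cccc(S(=O)(=O)N3CCC(N4CCC(C)CC4)CC3)c2)cc1` gives 2.4 h; the one single-point step, a 1.9-fold higher number from compound 1 to compound 3 (0.27 log units; within the scatter), is within the scatter. Compound 2 `Cc1nc(Cl)sc1S(=O)(=O)N1CCC(N2CCC(C)CC2)CC1` gives 0.167 h and stands lowest of the three numbers, beyond the scatter from both compound 1 and compound 3.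

Compound 4 `CC1CCN(C2CCN(S(=O)(=O)c3ccccc3Br)CC2)CC1` is not yet measured. It differs from compound 2 by 2-bromophenyl in place of 2-chloro-4-methyl-1,3-thiazol-5-yl on a sulfonyl sulfur. Going by the values given here, no measured step covers this kind of ring exchange on the sulfonyl sulfur; the only step in hand, a 1.9-fold higher number from compound 1 to compound 3 (0.27 log units; within the scatter), concerns a substituent on a ring that is not touched here and is within the scatter, so it gives no direction. What the numbers show is that compound 1 and compound 3, whose sulfonyl sulfur also carries a six-membered aromatic ring of carbon only, sit well above compound 2. On that basis an upward step beyond the scatter is expected, a 3.6-fold higher number from compound 2 to compound 4 (0.56 log units; beyond the scatter), though compound 4 lacks the second aromatic ring of compound 1 and compound 3, so the expectation stays below them. Compound 4 is estimated at 0.6 h, in the range 0.2 h to 1.8 h.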

Compound 4, half-life: 0.1 h
Compound 4: middle estimate off by 6.0-fold (0.78 log units), on the high side; the whole stated range lies above it.
By their numbers in this assay, from the lowest: compounds 4 and 2 (each within the scatter of the next); then compounds 1 and 3 (each within the scatter of the next).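

In this assay the exchange on the sulfonyl sulfur gives a 1.7-fold lower number from compound 2 to compound 4 (0.22 log units; within the scatter), so at this position the five-membered aromatic ring with 2 hetero atoms and the six-membered aromatic ring of carbon only cannot be told apart in this pair. The kind of ring on the sulfonyl sulfur therefore does not by itself set the number: compound 1 and compound 3 also carry a six-membered aromatic ring of carbon only there, and compound 4 still gives 0.1 h. No information on any property of these groups bears on this result.

Going by these compounds, it remains open whether a plain phenyl, a pyridine ring or a phenyl bearing a carboxylic acid on the sulfonyl sulfur would stand with compound 2 and compound 4, or with compound 1 and compound 3.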